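A few compounds are considered here, and "the series" means these few. Any claim that something is new, unique, unknown or untested is made for them only; others in the source may bear on it.

Compound 1 `O=C(N/N=C/c1ccc([N+](=O)[O-])cc1)c1ccncc1`: > 250000 nM
Compound 2 `O=C(N/N=C/c1ccccc1)c1ccncc1`: "not determined" (no result reported)

In an ADME assay on MCF7 cells (Homo sapiens) for cytotoxicity, read by MTT assay, with a stated time of 48 h (on this read-out higher numbers stand for weaker inhibition and lower numbers for stronger inhibition), compound 1 gives only a limit, > 250000 nM, which is a limit and not a number. For compound 2 the result in this assay is "not determined" (no result reported), so no figure shows where compound 2 stands. Of the values shown, one sits at a limit (the limit of > 250000 nM in this assay, at which 1 of the 2 values shown sits). Compound 3 `COc1ccc(/C=N/NC(=O)c2ccncc2)cc1` differs from compound 2 by methoxy in place of hydrogen on an aromatic carbon. Going by the values given here, no measured step exists to give the size of such a change, so no shift beyond the usual scatter of this assay is expected. Compound 3 is expected to give 250000 nM, somewhere between 40000 nM and 1000000 nM.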

Compound 3, half-maximal inhibitory concentration: > 250000 nM
Compound 3 gave a limit, no number (the forecaster's own chance of this, stated with the estimate: 70%); the middle value lies on the limit itself.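

No step can be read from compound 1 to compound 3, since both results are limits and not numbers: the limit of > 250000 nM in this assay, at which 2 of the 3 values shown sit.

The compounds shown leave open how much swapping nitro for methoxy shifts the result in this assay.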